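The source may report more compounds than this note shows. Statements on the series, on what has been measured and on what is new or still open speak of the compounds shown alone.

Notes on the sulfone-linked amide series. Compound 1 `O=C(NCc1ccc(S(=O)(=O)c2ccccc2)cc1)c1ccc2ccncc2c1` carries an unsubstituted phenyl on the sulfone and one aromatic amide core; in an ADME assay on microsomes from liver (Mus musculus) for metabolic stability, read by LC-MS, with a stated time of 30 min, tested at 1 uM (on this read-out lower numbers stand for a less stable compound and higher numbers for a more stable compound), compound 1 gives 3.3%. Among the measured compounds shown here, compound 2 `Cc1cccc(S(=O)(=O)c2ccc(CNC(=O)c3cc4cnccc4[nH]3)cc2)c1` carries a 3-methylphenyl on the sulfone and a different amide core; in this assay compound 2 gives 32%, the higher of the two numbers so far and beyond the scatter above compound 1. Because the two differ in more than one place, that gap says nothing about either change alone.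

Compound 3 `O=C(NCc1ccc(S(=O)(=O)c2ccccc2)cc1)c1cc2cnccc2[nH]1` keeps the core of compound 2 and differs from it by hydrogen in place of methyl on an aromatic carbon. For the measured compounds named here, no measured pair isolates this change, so the direction rests on expectation only. The step is expected to be a modest rise, a number 8 percentage points higher from compound 2 to compound 3 (within the scatter), possibly no more than the scatter. Compound 3 is expected to give about 40%, within 20% to 65%.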

Compound 3, percent of the compound remaining: 54%
Compound 3: the middle estimate sits 14 percentage points below what was measured; measured number inside the range.
By their numbers in this assay, from the lowest: compound 1; then compound 2; then compound 3.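

With the core of compound 2 held fixed, the change from 3-methylphenyl to phenyl on the sulfone can now be read on its own in this assay: hydrogen in place of methyl on the aromatic carbon gives a number 22 percentage points higher from compound 2 to compound 3 (beyond the scatter). This position, meta to a large group, therefore matters in this read-out, and on this core the unsubstituted phenyl gives the higher number, which the gap between the first two compounds could not show. Nothing measured here bears on the reason for this step.

As far as these compounds go, only methyl and hydrogen have been seen at this position on this core, so the effect of a chlorine, a methoxy group or an amine there remains open. From the compounds shown here alone, whether the same step holds on the core of compound 1 also remains open, as this is a single pair.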